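Isoquinolinone amides: ring-bearing amine variants at the carbonyl

This account rests on a few compounds, and the source may have more. Where it says the series, first, only, none or still open, it means among the compounds named here.

Measured compounds in an assay on isolated protein for inhibition of Rho-associated protein kinase 2 (Homo sapiens); on this read-out higher numbers stand for weaker inhibition and lower numbers for stronger inhibition:
- compound 1, `CC(C)N[C@H](C(=O)Nc1cc2cc[nH]c(=O)c2cc1Cl)C1CCCCC1`, 25 nM
- compound 2, `CC(C)[C@H](N)C(=O)Nc1cc2cc[nH]c(=O)c2cc1Cl`, 12 nM
- compound 3, `O=C(Nc1cc2cc[nH]c(=O)c2cc1Cl)[C@@H]1CCCN1`, 35 nM

Compound 3 carries the highest number of the three. Among the compounds with values here, its gap to compound 1 lies within the scatter, so no order between the two is claimed; its gap to compound 2 is beyond the scatter, the one step recorded in the set, a 2.9-fold higher number from compound 2 to compound 3 (0.46 log units; beyond the scatter).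

The next compound, compound 4, `N[C@H]1CC[C@H](C(=O)Nc2cc3cc[nH]c(=O)c3cc2Cl)CC1`, differs from compound 3 at the carbonyl carbon: 4-aminocyclohexyl in place of pyrrolidin-2-yl on a carbonyl carbon. Within the data shown here, only one measured step touches this position, the change from compound 2 to compound 3, and it was modest. The three measured amines all sit within a narrow band, so the data give no sign that another ring-bearing amine at this carbonyl moves the number far. A step within the scatter is therefore expected, in either direction, as a 1.2-fold lower number from compound 3 to compound 4 (0.07 log units; within the scatter). Compound 4 is accordingly estimated at 30 nM in this assay, within a range of 8 nM to 120 nM.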

Compound 4, half-maximal inhibitory concentration: 330 nM
Beside the measured number, compound 4's estimate is 11-fold (1.04 log units) below it; measured number above the stated range.
By their numbers in this assay, from the lowest: compound 2; then compounds 1 and 3 (each within the scatter of the next); then compound 4.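

In this assay, within the data shown here, this carbonyl position proves sensitive to the choice of ring-bearing amine: 4-aminocyclohexyl in place of pyrrolidin-2-yl gives a 9.4-fold higher number from compound 3 to compound 4 (0.97 log units; beyond the scatter) and, against the open-chain 1-amino-2-methylpropyl, gives a 28-fold higher number from compound 2 to compound 4 (1.44 log units; beyond the scatter) as the only step in the set graded large. The narrow band of compounds 1 to 3 therefore does not extend to every amine at this carbonyl, and a ring carrying an amine is not enough to hold the number there. No evidence on the origin of this weaker inhibition is at hand.

The change replaces a five-membered ring containing nitrogen with a six-membered carbon ring bearing an amino group, so these compounds cannot separate ring size from the place of the amine. Piperidin-2-yl and 3-aminocyclohexyl groups at this carbonyl would bear on that question.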